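The source may hold more compounds than are shown below. What is called first, only, known or untested is meant among the compounds shown, and "the series" means these compounds.

Measured compounds in an ADME assay on the whole organism with Oryza sativa as the target, tested at 0.1 uM; a higher number here means a weaker effect of the compound at the concentration tested, a lower number a stronger effect:
compound 1 `CCc1ccccc1NC(=O)N[C@H](C)c1ccccc1` gives 101%
compound 2 `COc1ccccc1NC(=O)N[C@H](C)c1ccccc1` gives 100%
compound 3 `COc1ccccc1NC(=O)N[C@@H](C)c1ccccc1` gives 98%

Compound 2 lies within the scatter of both others. Towards compound 1 the step is a number 1 percentage points lower from compound 1 to compound 2 (within the scatter); towards compound 3 it is a number 2 percentage points lower from compound 2 to compound 3 (within the scatter). Neither goes beyond the scatter, so the three values cannot be separated. The second step rests on (the fact that compounds 2 and 3 differ only in the configuration as drawn), so it concerns configuration alone.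

Compound 4 `C[C@@H](NC(=O)Nc1ccccc1Br)c1ccccc1` is not yet measured. It differs from compound 2 at one place: bromo in place of methoxy on an aromatic carbon. Among the compounds with values here, no measured step exchanges these two groups. Within the data shown here, the only measured exchange of a group on an aromatic carbon is a number 1 percentage points lower from compound 1 to compound 2 (within the scatter), and it stayed within the scatter. On that basis the expected step in this assay is a number 1 percentage points lower from compound 2 to compound 4 (within the scatter), nothing beyond the scatter, with the expected value staying close to the three measured ones. Compound 4 is therefore estimated at 99%, with a range from 88% to 108%. The estimate rests on a single within-scatter step and on three values that sit close together; a bromo group has not been tested in this series, so the range is kept somewhat wider than the scatter alone would call for.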

Compound 4, a percentage reported as activity, at one concentration (the size of the read-out at that concentration, not a potency): 99%
The estimate for compound 4 equals the measured number at the digits printed; the range from low to high includes it.
By their numbers in this assay, from the lowest: compounds 3, 4, 2 and 1 (each within the scatter of the next).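

In this assay bromo in place of methoxy on an aromatic carbon, ortho to a large group, gives a number 1 percentage points lower from compound 2 to compound 4 (within the scatter) and bromo in place of ethyl gives a number 2 percentage points lower from compound 1 to compound 4 (within the scatter) at the same place. The earlier exchange at this position involved only ethyl and methoxy; bromo now extends the comparison to a single heavy atom of bromine, and with methoxy leaving, the hydrogen-bond acceptor it carried goes too, yet compounds 1, 2 and 4 cannot be separated in this assay, and none of the three goes against that reading. No available evidence bears on this result or accounts for it.

As far as these compounds go, how an amine, a carboxylic acid or a longer chain would read at this place remains open, as does whether any group here can move the number beyond the scatter. The read-out also comes from one concentration and is not a potency, which leaves the behaviour of these compounds at other concentrations unknown.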